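Moving the fluorine around the outer phenyl ring

The source may hold more compounds than are shown below. What is called first, only, known or untested is meant among the compounds shown, and "the series" means these compounds.

Compound 1 `Cc1cc(-c2ccc(F)cc2)cc(C)c1Nc1ccnc(Nc2ccc(C#N)cc2)n1` is measured in an ADME assay on MT4 cells (Homo sapiens) for cytotoxicity, read by MTT assay, with a stated time of 4 days (on this read-out lower numbers stand for higher toxicity in this test and higher numbers for lower toxicity in this test), where compound 1 gives 4170 nM. Among the measured compounds shown here, the only other number belongs to compound 2 `Cc1cc(-c2cccc(Cl)c2)cc(C)c1Nc1ccnc(Nc2ccc(C#N)cc2)n1`, which gives 2160 nM in this assay; the step of a 1.9-fold lower number from compound 1 to compound 2 (0.29 log units; within the scatter) leaves the two indistinguishable. Compound 3 `Cc1cc(-c2ccccc2F)cc(C)c1Nc1ccnc(Nc2ccc(C#N)cc2)n1` differs from compound 1 by 2-fluorophenyl in place of 4-fluorophenyl on an aromatic carbon. For the measured compounds named here, no measured step shows what shifting the fluorine does; the one step known concerns another substitution and stays within the scatter. The expectation for compound 3 is therefore no step beyond the scatter, a 1.2-fold lower number from compound 1 to compound 3 (0.08 log units; within the scatter), giving an estimated 3500 nM with a range from 1500 nM to 8500 nM.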

Compound 3, half-maximal cytotoxic concentration: 2120 nM
For compound 3 the middle estimate is 1.7-fold (0.22 log units) above the measured one; measured number inside the range.
By their numbers in this assay, from the lowest: compounds 3, 2 and 1 (each within the scatter of the next).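

Among the compounds shown here, compound 3 gives the first reading of what moving the fluorine on this outer ring does: in this assay the change to 2-fluorophenyl is a 2.0-fold lower number from compound 1 to compound 3 (0.29 log units; within the scatter) and so cannot be told from no change. The comparison with the chlorinated ring gives a 1.0-fold lower number from compound 2 to compound 3 (0.01 log units; within the scatter) and agrees, so these three outer rings cannot be separated on this read-out. No measurement shown here offers an explanation for these numbers. Still open, as far as these compounds go, is whether an amine or a carboxylic acid on this ring would give a number beyond the scatter.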